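This account rests on a few compounds, and the source may have more. Where it says the series, first, only, none or still open, it means among the compounds named here.

Working notes on a small series tested in a functional assay on the whole organism for antagonist activity, with Mus musculus as the target; on this read-out lower numbers stand for an effect already at smaller amounts and higher numbers for an effect only at larger amounts of compound. Compound 1 `CSc1nc(-c2ccccc2)nn1C` gives > 200 mg/kg, which is a limit and not a number. Compound 2 `Cn1nc(-c2ccccc2)nc1S(C)(=O)=O` gives > 200 mg/kg, again a limit. Compound 3 `CSc1nc(-c2ccc(Cl)cc2)nn1C` gives > 200 mg/kg, also a limit, so its standing is known only as a limit. The whole picture so far is the limit of > 200 mg/kg in this assay, at which 3 of the 3 values shown sit.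

Compound 4 `Cn1nc(-c2ccc(Cl)cc2)nc1S(C)(=O)=O` is reached from compound 3 by methylsulfonyl in place of methylsulfanyl on an aromatic carbon, between two ring nitrogen atoms.

The same exchange without the chloro group is a step that the two limits leave unreadable from compound 1 to compound 2. The chloro exchange itself is a step that the two limits leave unreadable from compound 1 to compound 3. Neither gives a size, so the measured steps offer no basis for forecasting a shift in either direction in this assay, and no step beyond the scatter is expected. Compound 2 carries the methylsulfonyl group and shows no readable gain, which makes a reading at the limit the likeliest outcome for compound 4, although a measurable value cannot be ruled out. The expected change is a number no higher from compound 3 to compound 4 (the limit leaves the size open). For compound 4 the estimated value is 200 mg/kg, with an expected range from 70 mg/kg to 400 mg/kg.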

Compound 4, dose for half-maximal effect: > 200 mg/kg
Compound 4: only a limit was reported; the forecaster's own chance of this, stated with the estimate: 65%; the middle value sits exactly at the limit.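

Compound 4 gives only a limit, as do compound 2 and compound 3, so neither the methylsulfonyl exchange nor the chloro exchange yields a readable new step. The series stays at a single limit: the limit of > 200 mg/kg in this assay, at which 4 of the 4 values shown sit. The compounds shown leave open whether either exchange changes the effective dose at all, and in which direction.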